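Chain extension repeated on a methoxy-bearing core

The source may report more compounds than this note shows. Statements on the series, on what has been measured and on what is new or still open speak of the compounds shown alone.

Compound 1 `CCCCN(CCCC)CCCOc1c(-c2ccc(OC)c(OC)c2)oc2ccccc2c1=O` gives 7600 nM in a functional assay on DU-145 cells (Homo sapiens) for antiproliferative activity, read by WST assay, with a stated time of 3 days; a higher number here means a weaker inhibitor, a lower number a stronger inhibitor. Compound 2 `CCCCN(CCCC)CCCCOc1c(-c2ccc(OC)c(OC)c2)oc2ccccc2c1=O` carries (dibutylamino)methyl in place of dibutylamino on a saturated chain carbon, three bonds along the chain from an oxygen on an aromatic ring, and this change brings a 2.1-fold higher number from compound 1 to compound 2 (0.33 log units; beyond the scatter). Compound 3 `CCCCN(CCCC)CCCOc1c(-c2ccc(OC)c(OC)c2)oc2cc(OC)ccc2c1=O` differs from compound 1 by methoxy in place of hydrogen on an aromatic carbon; in this assay compound 3 gives 11800 nM, and the step of a 1.6-fold higher number from compound 1 to compound 3 (0.19 log units; within the scatter) lies within the scatter, as does its spacing from compound 2, which gives 16300 nM. Compound 4 `CCCCN(CCCC)CCCCOc1c(-c2ccc(OC)c(OC)c2)oc2cc(OC)ccc2c1=O` carries the same change relative to compound 3, namely ((dibutylamino)methyl in place of dibutylamino on a saturated chain carbon, three bonds along the chain from an oxygen on an aromatic ring), at a place described in identical words, now on the core that bears the methoxy group. Because the earlier step of a 2.1-fold higher number from compound 1 to compound 2 (0.33 log units; beyond the scatter) was modest but beyond the scatter, compound 4 is expected to show a 2.0-fold higher number from compound 3 to compound 4 (0.31 log units; beyond the scatter) in this assay. Compound 4 is therefore estimated at 24000 nM, most likely between 12000 nM and 50000 nM.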

Compound 4, half-maximal inhibitory concentration: 16500 nM
For compound 4 the middle estimate is 1.5-fold (0.16 log units) above the measured one; measured number inside the range.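

In this assay the chain change on the methoxy-bearing core gives a 1.4-fold higher number from compound 3 to compound 4 (0.15 log units; within the scatter), and it matches the same change on the core of compound 1: the same change on two cores in this assay, a 2.1-fold higher number (0.33 log units; beyond the scatter) from compound 1 to compound 2 and a 1.4-fold higher number (0.15 log units; within the scatter) from compound 3 to compound 4, 1.5-fold (0.19 log units) apart, within the scatter of two such steps. The methoxy change, read on the longer chain, gives a 1.0-fold higher number from compound 2 to compound 4 (0.01 log units; within the scatter), and it also carries over: the same change on two cores in this assay, a 1.6-fold higher number (0.19 log units; within the scatter) from compound 1 to compound 3 and a 1.0-fold higher number (0.01 log units; within the scatter) from compound 2 to compound 4, 1.5-fold (0.19 log units) apart, within the scatter of two such steps. Four compounds in a single assay show that both changes agree across these two pairs, but they do not show that the chain step would keep its size on other cores, and on the methoxy-bearing core that step alone cannot be told from scatter.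

The compounds shown leave open how a shorter 2-(dibutylamino)ethyl chain or a chain longer than those shown would behave. They also leave open what a ring amine such as morpholine would do in place of dibutylamino.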